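This account rests on a few compounds, and the source may have more. Where it says the series, first, only, none or still open, it means among the compounds named here.

Three compounds of the shared core have numbers in a functional assay on B16-F10 cells (Mus musculus) for antiproliferative activity, read by MTT assay, with a stated time of 48 h; on this read-out lower numbers stand for stronger inhibition and higher numbers for weaker inhibition. Compound 1 `COc1ccc(/C=C/c2cc(OC)cc(OC)c2/C=C/C(=O)c2ccc(Cl)c(Cl)c2)cc1` gives 7.5 ug/mL. Compound 2 `CCCC(C)Oc1ccc(C(=O)/C=C/c2c(/C=C/c3ccc(OC)cc3)cc(OC)cc2OC)cc1` gives 6.7 ug/mL, and compound 3 `COc1ccc(/C=C/c2cc(OC)cc(OC)c2/C=C/C(=O)c2ccc(Br)cc2)cc1` gives 6.5 ug/mL. Among the compounds with values here, the three differ only in the group on the carbonyl carbon, and no step between them leaves the scatter: a 1.1-fold lower number from compound 1 to compound 2 (0.05 log units; within the scatter), a 1.2-fold lower number from compound 1 to compound 3 (0.06 log units; within the scatter) and a 1.0-fold lower number from compound 2 to compound 3 (0.01 log units; within the scatter). On the numbers shown compound 2 stands second highest of the three, with compound 3 nearest and compound 1 furthest, both gaps within the scatter.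

Compound 4 `CCOc1ccc(C(=O)/C=C/c2c(/C=C/c3ccc(OC)cc3)cc(OC)cc2OC)cc1` is the next to be measured in this assay. Against compound 2 the change is hydrogen in place of propyl on a saturated chain carbon bound to an oxygen on an aromatic ring and a saturated chain carbon; read one bond further out, 1-methylbutoxy becomes ethoxy, so 4-(1-methylbutoxy)phenyl becomes 4-ethoxyphenyl. The step that bears most directly on it is a 1.0-fold lower number from compound 2 to compound 3 (0.01 log units; within the scatter), where the whole 1-methylbutoxy gave way to bromo and the number barely moved; a 1.1-fold lower number from compound 1 to compound 2 (0.05 log units; within the scatter) and a 1.2-fold lower number from compound 1 to compound 3 (0.06 log units; within the scatter) point the same way. Since a larger change at this group stayed within the scatter, the step of no change at the digits printed from compound 2 to compound 4 (within the scatter) is expected to stay within the scatter too, with no clear direction. Compound 4 is therefore estimated at 6.7 ug/mL in this assay, with a range from 4 ug/mL to 11.5 ug/mL.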

Compound 4, half-maximal inhibitory concentration: 6.4 ug/mL
Compound 4: middle estimate off by 1.0-fold (0.02 log units), on the high side; the measured number falls inside the stated range.
By their numbers in this assay, from the lowest: compounds 4, 3, 2 and 1 (each within the scatter of the next).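

In this assay, within the data shown here, this is the first change made within the alkoxy group itself: hydrogen in place of propyl on a saturated chain carbon, turning 1-methylbutoxy into ethoxy, gives a 1.0-fold lower number from compound 2 to compound 4 (0.02 log units; within the scatter). The 4-ethoxyphenyl group also reads level with the two halogenated aryl groups, with a 1.0-fold lower number from compound 3 to compound 4 (0.01 log units; within the scatter) and a 1.2-fold lower number from compound 1 to compound 4 (0.07 log units; within the scatter), so neither removing the propyl nor swapping ethoxy for bromo gives a readable step at this position. All four groups on the carbonyl carbon now lie within the scatter of one another, no compound of the four goes against this flat picture, and no evidence on hand accounts for it.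

The compounds shown carry only alkoxy and halogen substituents on this aryl ring, so it remains open whether a dimethylamino group, a carboxylic acid or a hydroxy group in place of ethoxy would stay within the scatter. From the compounds shown here alone, it also remains open whether a chain much longer than 1-methylbutoxy, such as decyloxy, would leave the number where it stands in this assay.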